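The source may hold more compounds than are shown below. What is called first, only, known or untested is meant among the compounds shown, and "the series" means these compounds.

Three compounds share one core and differ only in the group attached to a carbonyl carbon. Compound 1 `CC1CCCC(C(=O)N2CC(c3nc(-c4cccc(Cl)c4)no3)C2)C1` gives 410 nM in an assay on HEK293 cells for positive allosteric modulation of metabotropic glutamate receptor 5 (Homo sapiens), read by FLIPR; on this read-out lower numbers stand for an effect already at smaller amounts and higher numbers for an effect only at larger amounts of compound. Compound 2 `O=C(N1CCCCC1)N1CC(c2nc(-c3cccc(Cl)c3)no2)C1` gives 370 nM in this assay, and the step of a 1.1-fold lower number from compound 1 to compound 2 (0.04 log units; within the scatter) stays within the scatter. Compound 3 `O=C(C1CCC2(CCC2)CC1)N1CC(c2nc(-c3cccc(Cl)c3)no2)C1` gives 1100 nM in this assay, the highest of the three numbers; the steps of a 2.7-fold higher number from compound 1 to compound 3 (0.43 log units; beyond the scatter) and a 3.0-fold higher number from compound 2 to compound 3 (0.47 log units; beyond the scatter) both lie beyond the scatter, so compound 3 stands clearly apart from the other two.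

Compound 4 `COC1CCCN(C(=O)N2CC(c3nc(-c4cccc(Cl)c4)no3)C2)C1` has not yet been measured. The change from compound 3 to compound 4 is a group of 8 heavy atoms (6 carbon, 1 nitrogen, 1 oxygen; one six-membered non-aromatic ring with 1 hetero atom) in place of a group of 9 heavy atoms (9 carbon; one four-membered non-aromatic ring of carbon only, one six-membered non-aromatic ring of carbon only), on a carbonyl carbon. Compound 4 carries a 3-methoxypiperidin-1-yl group where compound 2 carries a plain piperidin-1-yl group, so the move from compound 3 to compound 4 largely undoes the earlier step. The most relevant comparison is a 3.0-fold higher number from compound 2 to compound 3 (0.47 log units; beyond the scatter). Running that step backwards suggests a lower number for compound 4, of a modest size, with the added methoxy group as the only unknown. Compound 4 is therefore expected to give about 400 nM in this assay, with a range from 180 nM to 900 nM. The estimated step is a 2.8-fold lower number from compound 3 to compound 4 (0.44 log units; beyond the scatter), a lower number than compound 3 shows.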

Compound 4, half-maximal effective concentration: > 10000 nM
Compound 4 ended at the assay's limit; the forecaster's own chance of this, stated with the estimate: 5%; middle value at least 25-fold (1.39 log units) from the limit.
By their numbers in this assay, from the lowest: compounds 2 and 1 (each within the scatter of the next); then compound 3. At a limit, above all of these: compound 4.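

The earlier compounds shown here showed the group on this carbonyl carbon changing the number little or only modestly, with a 1.1-fold lower number from compound 1 to compound 2 (0.04 log units; within the scatter) and a 2.7-fold higher number from compound 1 to compound 3 (0.43 log units; beyond the scatter). Putting methoxy in place of hydrogen on a saturated ring carbon of the piperidin-1-yl group has a much larger effect, an at least 27-fold higher number from compound 2 to compound 4 (1.43 log units; beyond the scatter), and the comparisons with the two carbon-only groups point the same way, with an at least 24-fold higher number from compound 1 to compound 4 (1.38 log units; beyond the scatter) and an at least 9.0-fold higher number from compound 3 to compound 4 (0.95 log units; beyond the scatter), so a small addition to a well-tolerated ring can matter more here than replacing the whole group did. Compound 4 stands at a limit and not at a measured number, so these steps give only the smallest possible size of the change: the limit of > 10000 nM in this assay, at which 1 of the 4 values shown sits.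

The compounds shown cannot separate the effect of the oxygen from that of simply having a substituent on the ring, and a piperidin-1-yl ring carrying a methyl or a hydroxyl group in place of the methoxy would bear on that. Going by these compounds, how far compound 4 actually lies past the limit also remains unknown.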